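Trifluoromethyl to chloro, with only a limit to go on

The source may hold more compounds than are shown below. What is called first, only, known or untested is meant among the compounds shown, and "the series" means these compounds.

In a physicochemical assay for solubility, read by nephelometry, in phosphate buffer, at pH 6.5 (a lower number here means a less soluble compound, a higher number a more soluble compound), compound 1 `N#Cc1cnc(NC(=O)CCCOc2ccccc2)s1` gives 1100 nM. Compound 2 `N#Cc1cnc(NC(=O)CCCOc2cccc(C(F)(F)F)c2)s1` has no exact number, and its result of < 1600 nM is a limit of the assay. Going by the values given here, the one measured step, trifluoromethyl in place of hydrogen on an aromatic carbon, is a step that the limit leaves unreadable from compound 1 to compound 2. That step therefore offers no size to carry forward.

Compound 3 `N#Cc1cnc(NC(=O)CCCOc2cccc(Cl)c2)s1` has chloro in place of trifluoromethyl on an aromatic carbon, meta to a large group: chloro in place of trifluoromethyl on an aromatic carbon. Among the compounds with values here, with no readable step to lean on, no change beyond the usual scatter is expected in either direction, so the expectation stays close to compound 1 at 1100 nM, the only exact value available. The estimated change is a step that the limit leaves unreadable from compound 2 to compound 3. Compound 3 is expected to read about 1000 nM, with an estimated range from 350 nM to 2800 nM.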

Compound 3, solubility: < 1600 nM
Compound 3: only a limit was reported (the forecaster's own chance of this, stated with the estimate: 45%); the middle value does not contradict the limit.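

Going by these compounds alone, compound 3, like compound 2, gives only a limit of the assay and not a number, so no step among compound 1, compound 2 and compound 3 can be read: the limit of < 1600 nM in this assay, at which 2 of the 3 values shown sit. From the compounds shown here alone, whether chloro or trifluoromethyl in place of hydrogen shifts the solubility reading at all, and in which direction, stays open.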